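Hydroxy Addition on a Deoxy Sugar with Two Alkyne Chains

The source may hold more compounds than are shown below. What is called first, only, known or untested is meant among the compounds shown, and "the series" means these compounds.

Compound 1 `CCCCCCC#Cc1cc2cn([C@H]3C[C@H](O)[C@@H](CO)O3)c(=O)nc2o1` and compound 3 `CCCCCCC#Cc1cc2cn([C@@H]3O[C@H](CO)[C@@H](O)[C@@H]3O)c(=O)nc2o1` differ only by hydroxy in place of hydrogen on a saturated ring carbon. In a functional assay on HEL cells (Homo sapiens) for cytotoxicity (a higher number here means that more compound is tolerated, a lower number that less compound is tolerated), compound 3 gives 133000 nM. For compound 1 the result in this assay is a limit of the assay, >= 97000 nM, as the limit of >= 97000 nM in this assay, at which 1 of the 3 values shown sits, shows. The hydroxy change therefore gives a step that the limit leaves unreadable from compound 1 to compound 3.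

Compound 2 `CCCCCCCCC#Cc1cc2cn([C@H]3C[C@H](O)[C@@H](CO)O3)c(=O)nc2o1` differs from compound 1 by ethyl in place of hydrogen on a saturated chain carbon, six bonds along the chain from a triple-bonded carbon. In this assay compound 2 gives 52000 nM, which amounts to an at least 1.8-fold lower number from compound 1 to compound 2 (0.27 log units; that floor lies within the scatter).

Compound 4 `CCCCCCCCC#Cc1cc2cn([C@@H]3O[C@H](CO)[C@@H](O)[C@H]3O)c(=O)nc2o1` has not yet been measured. It differs from compound 2 by hydroxy in place of hydrogen on a saturated ring carbon, the same change that separates compound 3 from compound 1. Since that step could not be read in the measured pair, the expectation rests on compound 3 alone, whose value of 133000 nM is the higher of the two readable numbers. Compound 4 is expected to show a 1.6-fold higher number from compound 2 to compound 4 (0.21 log units; within the scatter) in this assay. Compound 4 is estimated at 85000 nM, with a range from 40000 nM to 180000 nM.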

Compound 4, minimum cytotoxic concentration: 49000 nM
Beside the measured number, compound 4's estimate is 1.7-fold (0.24 log units) above it; the range from low to high includes it.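

In this assay, the hydroxy addition gives a 1.1-fold lower number from compound 2 to compound 4 (0.03 log units; within the scatter), so on the core of compound 2 the new hydroxy group leaves no difference that can be told from the scatter. The matching step on the shorter chain cannot be read, because compound 1 sits at a limit of the assay: the limit of >= 97000 nM in this assay, at which 1 of the 4 values shown sits. The series therefore offers a single readable pair, which shows that the change is tolerated on one core but does not show that it carries over from one core to another.

The drawn structures also give the hydroxy-bearing ring carbon opposite handedness in compound 3 and compound 4, which leaves open whether the two pairs represent quite the same change. The compounds shown also leave open how this cytotoxicity read-out would respond to an amine or a carboxylic acid at that ring carbon, or to a longer chain than that of compound 2.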